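Estimating Compound 3 from Two Measured Neighbours

A few compounds are considered here, and "the series" means these few. Any claim that something is new, unique, unknown or untested is made for them only; others in the source may bear on it.

- Compound 1 `COc1ccc(CN(C(=O)CSc2ccccn2)c2cc(OC)c(OC)c(OC)c2)cc1` gives 7510 nM
- Compound 2 `COc1ccc(CN(C(=O)CSc2nc3ccc(OC)cc3s2)c2cc(OC)c(OC)c(OC)c2)cc1` gives 20200 nM

In a functional assay on PC-3 cells (Homo sapiens) for antiproliferative activity, read by MTT assay, with a stated time of 48 h (a lower number here means a stronger inhibitor, a higher number a weaker inhibitor), compound 2, at 20200 nM, holds the higher of the two numbers and is thus the weaker inhibitor of the pair. Compound 3 `COc1ccc(CN(C(=O)CCSc2nc3ccccc3o2)c2cc(OC)c(OC)c(OC)c2)cc1` differs from it by a group of 11 heavy atoms (8 carbon, 1 nitrogen, 1 oxygen, 1 sulfur; one five-membered aromatic ring with 2 hetero atoms, one six-membered aromatic ring of carbon only) in place of a group of 12 heavy atoms (8 carbon, 1 nitrogen, 1 oxygen, 2 sulfur; one five-membered aromatic ring with 2 hetero atoms, one six-membered aromatic ring of carbon only), on a saturated chain carbon bound to a carbonyl carbon. Thus ((1,3-benzoxazol-2-yl)sulfanyl)methyl enters on a saturated chain carbon bound to a carbonyl carbon.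

Going by the values given here, only one measured step offers guidance: a 2.7-fold higher number from compound 1 to compound 2 (0.43 log units; beyond the scatter). That step placed 6-methoxy-1,3-benzothiazol-2-yl in place of pyridin-2-yl on a sulfur, and it was modest yet beyond the scatter. Among the compounds with values here, no measured pair shows a change at the place where compound 3 departs from compound 2, so the direction is uncertain. A small move toward lower numbers is expected, of similar or smaller size: a 1.7-fold lower number from compound 2 to compound 3 (0.23 log units; within the scatter). For compound 3 the estimated value is 12000 nM, with an expected range from 4000 nM to 35000 nM.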

Compound 3, half-maximal inhibitory concentration: 20200 nM
For compound 3 the middle estimate is 1.7-fold (0.23 log units) below the measured one; the measured number falls inside the stated range.
By their numbers in this assay, from the lowest: compound 1; then compounds 2 and 3 (each within the scatter of the next).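

In this assay, the replacement on a saturated chain carbon bound to a carbonyl carbon gives no change at the digits printed from compound 2 to compound 3 (within the scatter), so this position tolerates ((1,3-benzoxazol-2-yl)sulfanyl)methyl as well as the group it replaces, with no difference that can be read. Set against the pyridin-2-yl compound, the same group gives a 2.7-fold higher number from compound 1 to compound 3 (0.43 log units; beyond the scatter), a modest step of the same size as a 2.7-fold higher number from compound 1 to compound 2 (0.43 log units; beyond the scatter), so both groups with a five-membered and a six-membered aromatic ring stand on the weaker side of compound 1. Nothing available here explains this result.

The compounds shown do not separate the effect of the ring from that of the chain within this change. From the compounds shown here alone, whether an amine or a carboxylic acid at this place would bring the number below that of compound 1 remains open.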